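The source may hold more compounds than are shown below. What is called first, only, known or untested is meant among the compounds shown, and "the series" means these compounds.

Compound 1 `Cn1ccc(-c2cccc3c2CCC3c2ncc[nH]2)n1` is the starting point of this account. In a functional assay on CHO cells for agonist activity at Alpha-1B adrenergic receptor (Homo sapiens), read by FLIPR and calcium flux (a lower number here means that less compound is needed, a higher number that more compound is needed for the effect), compound 1 gives > 10000 nM, which is a limit of the assay rather than a number. Two further compounds sit at the same place. Compound 2 `CCS(=O)(=O)Nc1cccc(Cc2c[nH]cn2)c1` gives in this assay > 10000 nM, again a limit. Compound 3 `CS(=O)(=O)Nc1c(Cl)ccc2c1CCCC2c1ncc[nH]1` gives in this assay > 10000 nM, also a limit. Thus (the limit of > 10000 nM in this assay, at which 3 of the 3 values shown sit), and no measured value stands apart from it; compound 1 therefore cannot be ranked against compound 2 or compound 3 on these numbers.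

Compound 4 `c1cc(-c2nccs2)c2c(c1)C(c1ncc[nH]1)CC2` is the next compound and has not yet been measured. The change from compound 1 is 1,3-thiazol-2-yl in place of 1-methyl-1H-pyrazol-3-yl on an aromatic carbon. Going by the values given here, with every known value at the limit, there is no step between measured compounds to lean on. The step of a number no higher from compound 1 to compound 4 (the limit leaves the size open) is expected to be none beyond the scatter, because compound 1 gives > 10000 nM as a limit. Compound 4 is accordingly estimated at 10000 nM, with a range from 2000 nM to 30000 nM.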

Compound 4, half-maximal effective concentration: > 10000 nM
Compound 4: no number, only a limit; the forecaster's own chance of this, stated with the estimate: 75%; the middle value sits exactly at the limit.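

Going by these compounds alone, compound 1 and compound 4 both give only a limit in this assay, so no step between them can be read. The compounds shown leave open how any of them ranks and which change would give a measurable value, as all sit at one point: the limit of > 10000 nM in this assay, at which 4 of the 4 values shown sit.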